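Swapping a Pyrimidine Thioether for a Triazole Thioether

The compounds below may be only part of what the source reports. "The series", "measured", "known", "first", "only" and "open" are said of these compounds alone.

Compound 1 `N#Cc1ccc(-c2cs/c(=N/NC(=O)CSc3ncccn3)n2-c2ccccc2)cc1`: "not determined" (no result reported)
Compound 2 `O=C(CSc1ncccn1)N/N=c1/scc(-c2ccccc2)n1-c1ccccc1`: "not determined" (no result reported)
Compound 3 `O=C(CSc1ncccn1)N/N=c1/scc(-c2ccc(Br)cc2)n1-c1ccccc1`: > 200 ug/mL

In a functional assay on C6 cells (Rattus norvegicus) for cytotoxicity, read by MTT assay, with a stated time of 24 h (on this read-out higher numbers stand for weaker inhibition and lower numbers for stronger inhibition), compound 1 has no number of its own, and compound 2 likewise has none. Compound 3 gives only a limit of the assay, > 200 ug/mL. The single recorded entry therefore sits at the limit of > 200 ug/mL in this assay, at which 1 of the 3 values shown sits, so compound 1 cannot be placed on any scale. Compound 4 `Cn1cnnc1SCC(=O)N/N=c1/scc(-c2ccc(C#N)cc2)n1-c1ccccc1` differs from compound 1 in one place: 4-methyl-4H-1,2,4-triazol-3-yl in place of pyrimidin-2-yl on a sulfur. Among the measured compounds shown here, no measured pair shows this change, so the expected step in this assay is none beyond the scatter, with no direction to lean on. For compound 4 the estimated value is 200 ug/mL, expected to lie between 80 ug/mL and 400 ug/mL.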

Compound 4, half-maximal inhibitory concentration: > 200 ug/mL
Compound 4: no number, only a limit (the forecaster's own chance of this, stated with the estimate: 70%); the middle value sits exactly at the limit.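

In this assay compound 4 gives > 200 ug/mL as a limit of the assay and not a number. Among the compounds shown here, compound 1 has no number either, so no step between compound 1 and compound 4 can be read. The compounds shown leave open whether swapping pyrimidin-2-yl for 4-methyl-4H-1,2,4-triazol-3-yl changes the result at all.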